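The source may hold more compounds than are shown below. What is called first, only, known or untested is meant among the compounds shown, and "the series" means these compounds.

Working notes on the series. Three compounds share one core and have been run in a functional assay on PC-3 cells (Homo sapiens) for cytotoxicity, read by MTT assay, with a stated time of 72 h; a lower number here means a stronger inhibitor, a higher number a weaker inhibitor. Compound 1 `FC(F)(F)c1ccc(CSc2nc(N3CCCCC3)c3ccccc3n2)cc1` gives 25500 nM. Compound 2 `Cc1ccccc1Nc1nc(SCc2ccc(C(F)(F)F)cc2)nc2ccccc12` gives 36900 nM. Compound 3 `FC(F)(F)c1ccc(CSc2nc(Nc3cccc(C(F)(F)F)c3)c3ccccc3n2)cc1` gives 12900 nM, the lowest of the three numbers; the gap to compound 1 is within the scatter, the gap to compound 2 is beyond it. The step of a 2.0-fold lower number from compound 1 to compound 3 (0.30 log units; within the scatter) and the step of a 1.4-fold higher number from compound 1 to compound 2 (0.16 log units; within the scatter) both sit within the scatter, while the step of a 2.9-fold lower number from compound 2 to compound 3 (0.46 log units; beyond the scatter) is modest but beyond it.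

Compound 4 `Fc1ccc(Nc2nc(SCc3ccc(C(F)(F)F)cc3)nc3ccccc23)cc1` is not yet measured. It differs from compound 3 in one place: 4-fluorophenyl in place of 3-(trifluoromethyl)phenyl on a nitrogen on an aromatic ring. Among the compounds with values here, the only measured step that changes the group on that same nitrogen is the one from compound 2 to compound 3, where the 3-(trifluoromethyl)phenyl variant gave the lower number. Compound 4 moves away from that variant, so in this assay a number somewhat higher than that of compound 3 is expected, though a step of this size might also fall within the scatter; the expected step is a 1.7-fold higher number from compound 3 to compound 4 (0.23 log units; within the scatter). For compound 4 the estimate in this assay is 22000 nM, with a range from 9000 nM to 55000 nM.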

Compound 4, half-maximal inhibitory concentration: 7070 nM
For compound 4 the middle estimate is 3.1-fold (0.49 log units) above the measured one; measured number below the stated range.
By their numbers in this assay, from the lowest: compounds 4, 3, 1 and 2 (each within the scatter of the next, the first and the last beyond it).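

On the nitrogen, 4-fluorophenyl in place of 3-(trifluoromethyl)phenyl gives a 1.8-fold lower number from compound 3 to compound 4 (0.26 log units; within the scatter) in this assay, so the two groups cannot be told apart here and the trifluoromethyl group on the aniline ring is not needed to reach the low end of the series. The same group in place of 2-methylphenyl gives a 5.2-fold lower number from compound 2 to compound 4 (0.72 log units; beyond the scatter), and (4-fluorophenyl)amino in place of piperidin-1-yl on the aromatic carbon gives a 3.6-fold lower number from compound 1 to compound 4 (0.56 log units; beyond the scatter) as the first step from compound 1 that passes the scatter, whereas compound 2 and compound 3 stayed within the scatter of compound 1. No measurement on hand accounts for any of these steps.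

The compounds shown leave open whether the fluorine matters at all and whether its place on the ring does, which unsubstituted phenyl, 3-fluorophenyl or 4-chlorophenyl on the same nitrogen would address. They also leave open how an amine or a carboxylic acid on that ring, or a benzyl group in place of the aryl group on the nitrogen, would read in this assay on the shared core.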